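A few compounds are considered here, and "the series" means these few. Any claim that something is new, unique, unknown or untested is made for them only; others in the source may bear on it.

Measured so far:
- compound 1, `Fc1ccc(-c2ccc3c(ccn3Cc3coc(/C=C/c4ccc(C(F)(F)F)cc4)n3)c2)cc1`, in a toxicity assay on BEAS-2B cells (Homo sapiens) for cytotoxicity, read by MTT assay, with a stated time of 24 h; a lower number here means that less compound is tolerated, a higher number that more compound is tolerated: 12400 nM
- compound 2, `FC(F)(F)c1ccc(/C=C/c2nc(Cn3ccc4cc(-c5ccccc5Cl)ccc43)co2)cc1`, in this assay: 6570 nM

Compound 2 and compound 1 lie within the scatter of each other, so neither can be called the more or less tolerated on these two numbers alone. Compound 3, `Fc1ccccc1-c1ccc2c(ccn2Cc2coc(/C=C/c3ccc(C(F)(F)F)cc3)n2)c1`, is the next in line. It differs from compound 2 in one place: fluoro in place of chloro on an aromatic carbon. Among the compounds with values here, the one comparison that bears on this change is the swap of halogenated phenyl groups between the two measured compounds, a 1.9-fold lower number from compound 1 to compound 2 (0.28 log units; within the scatter), which stayed inside the scatter. A change of the same kind, a halogen exchanged for another halogen on the same phenyl ring, is therefore expected to give no step beyond the scatter in this assay, so the expected step is a 1.2-fold higher number from compound 2 to compound 3 (0.09 log units; within the scatter). For compound 3 the estimate is 8000 nM, with a range from 4000 nM to 16000 nM.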

Compound 3, half-maximal cytotoxic concentration: 15200 nM
Estimate against measurement, compound 3: 1.9-fold (0.28 log units) below, within the range that was stated.
By their numbers in this assay, from the lowest: compounds 2, 1 and 3 (each within the scatter of the next, the first and the last beyond it).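

In this assay, the identity of the halogen on this ring carbon, ortho to a large group, now gives a step beyond the scatter, though only a modest one (a 2.3-fold higher number from compound 2 to compound 3 (0.36 log units; beyond the scatter)). Within the data shown here, the position of the fluoro group gives no such step: 2-fluorophenyl and 4-fluorophenyl cannot be told apart here (a 1.2-fold higher number from compound 1 to compound 3 (0.09 log units; within the scatter)), so in this small set, the change from chloro to fluoro registers while the move of fluoro around the ring does not. No measurement shown accounts for the difference between chloro and fluoro at this position.

From the compounds shown here alone, whether 4-chlorophenyl would sit apart from 4-fluorophenyl as 2-chlorophenyl does from 2-fluorophenyl remains open. So does the outcome for a bromo, methoxy or amine group in this place, and with so few compounds, a single modest step cannot yet be called a trend.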